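Replacing Nitro with Methoxy on the Benzyl Group

This account rests on a few compounds, and the source may have more. Where it says the series, first, only, none or still open, it means among the compounds named here.

In a functional assay on HCT-116 cells (Homo sapiens) for antiproliferative activity, read by MTT assay, with a stated time of 48 h (a lower number here means a stronger inhibitor, a higher number a weaker inhibitor), compound 3 `COc1ccc(CN(C(=O)CSc2nc3ccccc3s2)c2cc(OC)c(OC)c(OC)c2)cc1[N+](=O)[O-]` gives 1280 nM as the middle of three numbers. Compound 2 `COc1ccc(CN(C(=O)CSc2nc3ccccc3s2)c2cc(OC)c(OC)c(OC)c2)cc1O` gives 182 nM as the lowest and compound 1 `COc1ccc(CN(C(=O)CSc2nc3ccccc3s2)c2cc(OC)c(OC)c(OC)c2)cc1N=[N+]=[N-]` gives 2860 nM as the highest.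

The next change methoxy in place of nitro on an aromatic carbon puts methoxy in place of nitro on an aromatic carbon, ortho to a methoxy group, and gives compound 4 `COc1ccc(CN(C(=O)CSc2nc3ccccc3s2)c2cc(OC)c(OC)c(OC)c2)cc1OC` with its 3,4-dimethoxybenzyl group. Three measured steps alter this same place. Hydroxy replacing azido gave a 16-fold lower number from compound 1 to compound 2 (1.20 log units; beyond the scatter) and nitro replacing azido gave a 2.2-fold lower number from compound 1 to compound 3 (0.35 log units; beyond the scatter) while nitro replacing hydroxy gave a 7.0-fold higher number from compound 2 to compound 3 (0.85 log units; beyond the scatter) in the opposite direction.

Methoxy itself is untested here, but of the three groups measured, hydroxy is nearest to it in structure. That makes compound 2 at 182 nM the closest guide, though not an exact one. A modest fall in the number is therefore expected, and the estimated step is a 4.0-fold lower number from compound 3 to compound 4 (0.60 log units; beyond the scatter) in this assay on this reasoning. Compound 4 is estimated at 320 nM (expected range 90 nM to 1100 nM).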

Compound 4, half-maximal inhibitory concentration: 33900 nM
Compound 4: the middle estimate sits 110-fold (2.03 log units) below what was measured; measured number above the stated range.
By their numbers in this assay, from the lowest: compound 2; then compound 3; then compound 1; then compound 4.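

In this assay, putting a methyl on the oxygen of the hydroxy group is the largest step seen at this position (a 190-fold higher number from compound 2 to compound 4 (2.27 log units; beyond the scatter)), so a hydroxy and a methoxy here are far from interchangeable, despite differing by one methyl. Methoxy also falls behind the other two groups (a 26-fold higher number from compound 3 to compound 4 (1.42 log units; beyond the scatter); a 12-fold higher number from compound 1 to compound 4 (1.07 log units; beyond the scatter)), leaving compound 4 the weakest of the four and showing that a small change at this one position can have a very large effect on the number. Nothing available here explains why this methyl matters so much.

The compounds shown leave open where an amine, a fluorine atom or a longer chain on the oxygen, such as ethoxy, would fall between compound 2 and compound 4. From the compounds shown here alone, whether the same order of groups would hold on a different core also remains open.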